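Replacing ethoxy with chloro on the most potent compound

The compounds below may be only part of what the source reports. "The series", "measured", "known", "first", "only" and "open" are said of these compounds alone.

In a functional assay on A549 cells (Homo sapiens) for antiproliferative activity, read by MTT assay, with a stated time of 72 h (a lower number here means a stronger inhibitor, a higher number a weaker inhibitor), compound 3 `CCOc1ccc(-c2ncnn2-c2cc(OC)c(OC)c(OC)c2)cc1Cl` gives 10 nM, the lowest number of the three measured. Compound 2 `COc1ccc(-c2ncnn2-c2cc(OC)c(OC)c(OC)c2)cc1` gives 520 nM, and compound 1 `COc1cc(-n2ncnc2-c2ccc(C)cc2)cc(OC)c1OC` gives 1100 nM. Compound 4 `COc1cc(-n2ncnc2-c2ccc(Cl)c(Cl)c2)cc(OC)c1OC` is unmeasured and differs from compound 3 in one place: chloro in place of ethoxy on an aromatic carbon. Among the compounds with values here, no measured step makes this exact swap. The closest guide is a 2.1-fold lower number from compound 1 to compound 2 (0.33 log units; beyond the scatter), a modest change from methoxy in place of methyl on an aromatic carbon. That step suggests that losing the ethoxy group could cost potency in this assay, though its size is uncertain. A large rise is expected, an estimated 25-fold higher number from compound 3 to compound 4 (1.40 log units; beyond the scatter). For compound 4 the estimated value is 250 nM, with an expected range of 50 nM to 1200 nM.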

Compound 4, half-maximal inhibitory concentration: > 10000 nM
Compound 4: a limit, no number; the forecaster's own chance of this, stated with the estimate: 3%; middle value at least 40-fold (1.60 log units) away from the limit.
By their numbers in this assay, from the lowest: compound 3; then compound 2; then compound 1. At a limit, above all of these: compound 4.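

In this assay compound 4 stands at a limit, not a number: the limit of > 10000 nM in this assay, at which 1 of the 4 values shown sits. At this position, ortho to a chloro group, the ethoxy group matters greatly, as chloro in its place gives an at least 1000-fold higher number from compound 3 to compound 4 (3.00 log units; beyond the scatter). The 3,4-dichlorophenyl group also falls behind both single-substituent rings, with an at least 19-fold higher number from compound 2 to compound 4 (1.28 log units; beyond the scatter) and an at least 9.0-fold higher number from compound 1 to compound 4 (0.95 log units; beyond the scatter). Still open, on these data alone, is whether potency depends on the oxygen of the ethoxy group or on its carbons. A propoxy chain or an amine on this carbon could begin to separate the two.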